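Swapping the Aryl Group on the Amide Nitrogen

A few compounds are considered here, and "the series" means these few. Any claim that something is new, unique, unknown or untested is made for them only; others in the source may bear on it.

In an in vitro ADME assay on microsomes from liver (Homo sapiens) for pharmacokinetics, read by LC-MS, with a stated time of 10 min, tested at 1 uM (a higher number here means faster removal of the compound, a lower number slower removal), compound 1 (`CN1C[C@H](C(=O)Nc2ccc(C3CC3)cc2)[C@@H](c2ccc(/C=C/C(=O)Nc3ccccc3N)cc2)C1`) gives 12 mL/min/kg and compound 2 (`CN1C[C@H](C(=O)Nc2ccc(Br)cc2)[C@@H](c2ccc(/C=C/C(=O)Nc3ccccc3N)cc2)C1`) gives 3 mL/min/kg while compound 3 (`CN1C[C@H](C(=O)Nc2ccccc2F)[C@@H](c2ccc(/C=C/C(=O)Nc3ccccc3N)cc2)C1`) gives 10 mL/min/kg on the same scale. Compound 3 thus stands level with compound 1 and clearly above compound 2. Compound 4 (`Cc1cc(NC(=O)[C@H]2CN(C)C[C@@H]2c2ccc(/C=C/C(=O)Nc3ccccc3N)cc2)ccc1F`) carries 4-fluoro-3-methylphenyl in place of 2-fluorophenyl on an amide-type nitrogen. Two measured exchanges at that nitrogen bear on this, namely a 1.2-fold lower number from compound 1 to compound 3 (0.08 log units; within the scatter) and a 3.3-fold higher number from compound 2 to compound 3 (0.52 log units; beyond the scatter) in the opposite sense. Neither involves the entering group, and only compound 2 stands apart, with a 4.0-fold lower number from compound 1 to compound 2 (0.60 log units; beyond the scatter) as the step that separates it. The expected move is therefore a 1.3-fold lower number from compound 3 to compound 4 (0.10 log units; within the scatter) in this assay and nothing beyond the scatter is anticipated. Compound 4 is estimated at 8 mL/min/kg with a range from 3.5 mL/min/kg to 18 mL/min/kg in this measurement.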

Compound 4, clearance: 15 mL/min/kg
Compound 4: middle estimate off by 1.9-fold (0.27 log units), on the low side, and the stated range covers the measured number.
By their numbers in this assay, from the lowest: compound 2; then compounds 3, 1 and 4 (each within the scatter of the next).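

In this assay the 4-fluoro-3-methylphenyl group on the amide-type nitrogen falls in with the 2-fluorophenyl and 4-cyclopropylphenyl groups, with a 1.5-fold higher number from compound 3 to compound 4 (0.18 log units; within the scatter) and a 1.3-fold higher number from compound 1 to compound 4 (0.10 log units; within the scatter) both within the scatter. Against the 4-bromophenyl group the picture differs, with a 5.0-fold higher number from compound 2 to compound 4 (0.70 log units; beyond the scatter) beyond the scatter, so compound 2 alone stands apart among three other aryl groups. Nothing available explains why this one group separates.

As far as these compounds go, whether the separation belongs to bromo itself remains open, since chloro or iodo in its place could show this. From the compounds shown here alone, the effect of an amine or a carboxylic acid on this aryl group also remains open.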